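Swapping Fluoro for an Amide on a Weak Compound

This account rests on a few compounds, and the source may have more. Where it says the series, first, only, none or still open, it means among the compounds named here.

Compound 1 `CC[C@@H]1C(=O)N(C)c2cnc(-n3ccc4cc(C(N)=O)ccc43)nc2N1C1CCCC1`: 1830 nM
Compound 2 `CCC1C(=O)N(C)c2cnc(-n3ccc4cc(F)ccc43)nc2N1c1ccn(C)n1`: 24700 nM

In a functional assay on MCF7 cells (Homo sapiens) for antiproliferative activity, read by CCK-8 assay, with a stated time of 72 h (a higher number here means a weaker inhibitor of growth, a lower number a stronger inhibitor of growth), compound 2, at 24700 nM, has the higher of the two numbers, and its gap to compound 1 lies beyond the usual scatter. Going by the values given here, with only two measurements, this shows little more than that compound 2 is the weaker inhibitor of growth.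

Compound 3 `CCNC(=O)c1ccc2c(ccn2-c2ncc3c(n2)N(c2ccn(C)n2)C(CC)C(=O)N3C)c1` has the structure of compound 2 with one change: ethylcarbamoyl in place of fluoro on an aromatic carbon.

Among the compounds with values here, no measured pair isolates this change. Compound 1 also carries an amide group and gives 1830 nM, but it differs from compound 2 elsewhere too, so it is only a loose guide. A lower number is therefore expected, with an estimated 4.1-fold lower number from compound 2 to compound 3 (0.61 log units; beyond the scatter). For compound 3 the estimated value is 6000 nM, with an expected range of 1500 nM to 25000 nM.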

Compound 3, concentration for 50% growth inhibition: 13200 nM
Compound 3: the middle estimate sits 2.2-fold (0.34 log units) below what was measured; the range from low to high includes it.
By their numbers in this assay, from the lowest: compound 1; then compounds 3 and 2 (each within the scatter of the next).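

In this assay, placing ethylcarbamoyl in place of fluoro on this aromatic carbon gives a 1.9-fold lower number from compound 2 to compound 3 (0.27 log units; within the scatter), so the two compounds cannot be told apart. Going by these compounds alone, this is the first direct reading of the position: with everything else in the molecule held fixed, the much larger group, which brings a carbonyl and an amide hydrogen, leaves growth inhibition unchanged within the scatter. No supporting measurement is available to explain why this swap has so little effect.

Going by these compounds, whether an amine, a carboxylic acid or a longer chain on the amide nitrogen at this carbon would move the number beyond the scatter remains open. So does whether the same swap would give a similar result on the core of compound 1.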